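The source may hold more compounds than are shown below. What is called first, only, known or untested is meant among the compounds shown, and "the series" means these compounds.

Measured compounds in a functional assay on T47D cells (Homo sapiens) for inhibition, read by sulforhodamine B assay, with a stated time of 48 h; a higher number here means a weaker inhibitor of growth, a lower number a stronger inhibitor of growth:

Compound 1 `COc1cc(C)cc(-c2c(-c3ccnc(-c4ccc(C(C)=O)cc4)c3)cnn2CC#N)c1` gives 2420 nM.
Compound 2 `Cc1cc(O)cc(-c2nn(CC#N)cc2-c2ccnc(-c3ccc(Oc4ccccc4)cc3)c2)c1` gives 2040 nM.
Compound 3 `COc1cc(C)cc(-c2nn(CC#N)cc2-c2ccnc(-c3ccc(N(C)C)cc3)c2)c1` gives 475 nM.

Among these three, compound 3 stands lowest and is the strongest growth inhibitor; its gap to compound 2 and to compound 1 lies beyond the usual scatter, while compound 1 and compound 2 sit within scatter of each other.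

Compound 4 `Cc1cc(O)cc(-c2nn(CC#N)cc2-c2ccnc(-c3ccc(N(C)C)cc3)c2)c1` has not yet been measured. It differs from compound 3 in one place: hydrogen in place of methyl on an oxygen on an aromatic ring, that is, methoxy becomes hydroxy on the 3-methoxy-5-methylphenyl group. Going by the values given here, no measured pair shows this change alone, so its effect here is unknown. The expected step from compound 3 to compound 4 in this assay is a 1.2-fold higher number from compound 3 to compound 4 (0.06 log units; within the scatter), likely no change beyond the scatter. Compound 4 is therefore estimated at 550 nM, between 200 nM and 1600 nM.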

Compound 4, concentration for 50% growth inhibition: 2590 nM
Compound 4: middle estimate off by 4.7-fold (0.67 log units), on the low side, outside the stated range (above it).
By their numbers in this assay, from the lowest: compound 3; then compounds 2, 1 and 4 (each within the scatter of the next).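

On the 3-methoxy-5-methylphenyl group, the methyl on the oxygen matters: changing methoxy to hydroxy gives a 5.5-fold higher number from compound 3 to compound 4 (0.74 log units; beyond the scatter) and so a weaker inhibitor of growth. With hydroxy or its equivalent position held fixed, dimethylamino in place of phenoxy gives a 1.3-fold higher number from compound 2 to compound 4 (0.10 log units; within the scatter) and so does not separate these two groups on that hydroxy-bearing background. Going by these compounds, whether ethoxy, a longer chain on that oxygen, or an amine in place of the hydroxy would keep the strength of compound 3 stays open. Nothing measured here gives a reason for the methoxy result.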